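Swapping the Aryl Group on the Shared Core

This account rests on a few compounds, and the source may have more. Where it says the series, first, only, none or still open, it means among the compounds named here.

Compound 1, `CC1=CC[C@H](C(C)(C)N=C=S)CC1`: in a functional assay on HT-29 cells (Homo sapiens) for inhibition, read by sulforhodamine B assay, with a stated time of 48 h (on this read-out higher numbers stand for weaker inhibition of growth and lower numbers for stronger inhibition of growth), compound 1 gives only a limit, > 100000 nM.
Compound 2, `COc1ccc(/C=N/NC(=S)NC(C)(C)[C@H]2CC=C(C)CC2)cc1`: in this assay compound 2 gives 8400 nM.
Compound 3, `CC1=CC[C@H](C(C)(C)NC(=S)N/N=C/c2ccccc2O)CC1`: in this assay compound 3 gives 10900 nM.

Among the numbers shown, compound 3 carries the highest one, and its nearest neighbour is compound 2, which sits at a lower number. That step, a 1.3-fold higher number from compound 2 to compound 3 (0.11 log units; within the scatter), is within the scatter, so the two compounds are not told apart by this read-out. The result for compound 1 is a limit of the assay, not a number, as recorded in the limit of > 100000 nM in this assay, at which 1 of the 3 values shown sits.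

The unmeasured compound is compound 4, `CC1=CC[C@H](C(C)(C)NC(=S)N/N=C/c2ccc(Cl)cc2)CC1`. It differs from compound 3 in one place: 4-chlorophenyl in place of 2-hydroxyphenyl on a carbon with a double bond to nitrogen. Within the data shown here, the one measured step that bears on this change is the exchange of one aryl group for another at the same place, from compound 2 to compound 3, and that exchange moved the number very little (a 1.3-fold higher number from compound 2 to compound 3 (0.11 log units; within the scatter)). Among the measured compounds shown here, no measured compound carries a 4-chlorophenyl group, so the expectation rests on that single step. The estimated step of a 1.4-fold lower number from compound 3 to compound 4 (0.13 log units; within the scatter) is therefore expected to stay within the scatter, with no clear direction. Compound 4 is estimated to give about 8000 nM in this assay, with a range from 3000 nM to 25000 nM.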

Compound 4, concentration for 50% growth inhibition: 13600 nM
The estimate for compound 4 lay 1.7-fold (0.23 log units) below the measured number; the measured number falls inside the stated range.
By their numbers in this assay, from the lowest: compounds 2, 3 and 4 (each within the scatter of the next). At a limit, above all of these: compound 1.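

With 4-chlorophenyl on the carbon with a double bond to nitrogen, this place has now held three aryl groups, and this assay does not tell them apart. Exchanging 2-hydroxyphenyl, which counts a hydrogen-bond donor and a hydrogen-bond acceptor, for 4-chlorophenyl, which counts neither, gives a 1.2-fold higher number from compound 3 to compound 4 (0.10 log units; within the scatter) and so leaves the read-out within its usual scatter, while chloro in place of methoxy on an aromatic carbon gives a 1.6-fold higher number from compound 2 to compound 4 (0.21 log units; within the scatter) and stays within that scatter too. Nothing measured here offers a reason for this lack of separation.

On these data alone, these three aryl groups span only a small part of what could sit at this place, so it remains open whether an aryl group carrying an amine or a carboxylic acid would be separated from them in this assay by more than the scatter. As far as these compounds go, it is also open whether this place needs an aromatic ring at all, since a cyclohexyl group or a longer carbon chain there would test that directly.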